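A few compounds are considered here, and "the series" means these few. Any claim that something is new, unique, unknown or untested is made for them only; others in the source may bear on it.

In a physicochemical assay for lipophilicity, using the shake flask method (on this read-out lower numbers stand for lower lipophilicity and higher numbers for higher lipophilicity), the three measured compounds read as follows:

compound 1, `CC(C)(C)OC(=O)N/N=C/c1c(N)ncnc1Oc1ccc(NC(=O)C2(C(=O)Nc3ccc(F)cc3)CC2)cc1F`, gives 3.7
compound 2, `C=CCO/N=C/c1c(N)ncnc1Oc1ccc(NC(=O)C2(C(=O)Nc3ccc(F)cc3)CC2)cc1F`, gives 3.65
compound 3, `Nc1ncnc(Oc2ccc(NC(=O)C3(C(=O)Nc4ccc(F)cc4)CC3)cc2F)c1/C=N/OCC(=O)N1CCOCC1`, gives 2.1

Compound 3 stands lowest of the three. Its distance from the other two is clear: a number 1.60 log units lower from compound 1 to compound 3 (beyond the scatter) and a number 1.55 log units lower from compound 2 to compound 3 (beyond the scatter), both well beyond the scatter. Compounds 1 and 2, by contrast, sit together, since a number 0.05 log units lower from compound 1 to compound 2 (within the scatter).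

Compound 4, `CCO/N=C/c1c(N)ncnc1Oc1ccc(NC(=O)C2(C(=O)Nc3ccc(F)cc3)CC2)cc1F`, has not yet been measured in this assay. Relative to compound 3 it carries this change: methyl in place of (morpholin-4-yl)carbonyl on a saturated chain carbon bound to an oxygen. For the measured compounds named here, the step that bears most directly on this is the one from compound 2 to compound 3, where the same eight-atom group entered at the same place and the number fell sharply: a number 1.55 log units lower from compound 2 to compound 3 (beyond the scatter). Compound 4 removes that group again, so the expectation is a step of similar size in the opposite direction, back toward the region where compounds 1 and 2 lie. The small difference between vinyl in compound 2 and methyl in compound 4 is not covered by any measured step, so the estimate leans only on the large step above. For compound 4 the expected step is a number 1.30 log units higher from compound 3 to compound 4 (beyond the scatter). Compound 4 is therefore estimated at 3.4, with a range from 3 to 3.8.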

Compound 4, partition coefficient: 3.41
Compound 4: middle estimate off by 0.01 log units, on the low side, within the range that was stated.
By their numbers in this assay, from the lowest: compound 3; then compounds 4, 2 and 1 (each within the scatter of the next).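

In this assay the swap of (morpholin-4-yl)carbonyl for methyl gives a number 1.31 log units higher from compound 3 to compound 4 (beyond the scatter) and so shows that the large gap seen when this group stands in place of vinyl also appears against a second small group on the same saturated chain carbon. Compound 4 also falls in with the other two, with a number 0.24 log units lower from compound 2 to compound 4 (within the scatter) and a number 0.29 log units lower from compound 1 to compound 4 (within the scatter) and thus ethoxy, allyloxy and (tert-butoxycarbonyl)amino on the double-bonded nitrogen cannot be told apart here, while compound 3 alone stands apart from all of them. Nothing shown explains the size of this large step.

Open, from the compounds shown here alone, is how much of that step belongs to the ring of (morpholin-4-yl)carbonyl and how much to its carbonyl, a question that a dimethylaminocarbonyl or a piperidin-1-ylcarbonyl group at the same place would bear on. Also open, going by these compounds, is where a longer chain such as butoxy, an amine such as aminoethoxy or a carboxylic acid such as carboxymethoxy would fall on this read-out.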